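Permeability notes: furan to hydroxymethoxyphenyl swap on two cores

A few compounds are considered here, and "the series" means these few. Any claim that something is new, unique, unknown or untested is made for them only; others in the source may bear on it.

Compound 2 `CC(C)(C)c1ccc(-c2ccc3c(NCCCNCc4ccco4)ccnc3c2)cc1` and compound 1 `COc1cccc(CNCCCNc2ccnc3cc(-c4ccc(C(C)(C)C)cc4)ccc23)c1O` share one core; compound 3 `FC(F)(F)c1cc(-c2ccc3c(NCCCNCc4ccco4)ccnc3c2)cc(C(F)(F)F)c1` and compound 4 `COc1cccc(CNCCCNc2ccnc3cc(-c4cc(C(F)(F)F)cc(C(F)(F)F)c4)ccc23)c1O` share another. The difference between the two cores is not broken down here. In an ADME assay for permeability, using PAMPA, with a stated time of 30 min, at pH 7.4 (a higher number here means that the compound crosses the layer faster, a lower number that the compound crosses the layer more slowly), compound 2 gives 237 10^-6 cm/s, compound 1 gives 237 10^-6 cm/s and compound 3 gives 237 10^-6 cm/s. The change from compound 2 to compound 1 is 2-hydroxy-3-methoxyphenyl in place of furan-2-yl on a saturated chain carbon bound to an amine nitrogen, and the step it made is no change at the digits printed from compound 2 to compound 1 (within the scatter). The same change, (2-hydroxy-3-methoxyphenyl in place of furan-2-yl on a saturated chain carbon bound to an amine nitrogen), is made from compound 3 to compound 4, at the same place. For this pair the expected step is no change at the digits printed from compound 3 to compound 4 (within the scatter), a flat reading, because no change at the digits printed from compound 2 to compound 1 (within the scatter) on the other core stayed within the scatter, and compound 3 already sits level with compounds 1 and 2. Compound 4 is accordingly estimated at 237 10^-6 cm/s, with a range expected from 120 10^-6 cm/s to 470 10^-6 cm/s.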

Compound 4, apparent permeability: 237 10^-6 cm/s
The estimate for compound 4 equals the measured number at the digits printed; the measured number falls inside the stated range.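

In this assay, putting 2-hydroxy-3-methoxyphenyl in place of furan-2-yl on a saturated chain carbon bound to an amine nitrogen gives no change at the digits printed from compound 3 to compound 4 (within the scatter) on the second core. The change therefore reads flat on both cores shown, and the two steps agree: the same change on two cores in this assay, no change at the digits printed (within the scatter) from compound 2 to compound 1 and no change at the digits printed (within the scatter) from compound 3 to compound 4, 1.0-fold (0.00 log units) apart, within the scatter of two such steps. This shows that the flat result carried across these two cores, but it does not show that it would carry to any other core in the series.

The compounds shown leave open whether a carboxylic acid in place of furan-2-yl would shift the reading in this assay. They also leave open whether a longer chain carrying the amine nitrogen would do so.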